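A few compounds are considered here, and "the series" means these few. Any claim that something is new, unique, unknown or untested is made for them only; others in the source may bear on it.

Measured so far:
compound 1 `C(#Cc1nc2c(s1)CN(C1CCCCC1)CC2)c1ccccc1` — in an assay on HEK293 cells for positive allosteric modulation of metabotropic glutamate receptor 5 (Homo sapiens), read by FLIPR, with a stated time of 1 h (a higher number here means that more compound is needed for the effect, a lower number that less compound is needed), compound 1 gives > 10000 nM
compound 2 `CC1CCCC(C(=O)N2CCc3nc(C#Cc4ccccc4)sc3C2)C1` — in this assay compound 2 gives 100 nM

Compound 1 stands only at a limit of this assay: its entry, > 10000 nM, is a limit and not a number, so it sits at the limit of > 10000 nM in this assay, at which 1 of the 2 values shown sits, rather than at a measured value. Compound 2, which carries a carbonyl on the amine nitrogen in a ring, gives 100 nM in this assay. Compound 3 `O=C(C1CCOCC1)N1CCc2nc(C#Cc3ccccc3)sc2C1` has not yet been measured; it differs from compound 1 by (oxan-4-yl)carbonyl in place of cyclohexyl on an amine nitrogen in a ring. The entering group is also a carbonyl on that nitrogen, and compound 2 with its 100 nM shows what a carbonyl-bearing member of the series can reach. The step of an at least 33-fold lower number from compound 1 to compound 3 (1.52 log units; beyond the scatter) is therefore expected to be large and toward lower values, beyond the scatter. Compound 3 is expected to give about 300 nM, within a range of 60 nM to 1500 nM.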

Compound 3, half-maximal effective concentration: 290 nM
For compound 3 the middle estimate is 1.0-fold (0.01 log units) above the measured one, within the range that was stated.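

In this assay, placing (oxan-4-yl)carbonyl on the amine nitrogen in a ring instead of cyclohexyl gives an at least 34-fold lower number from compound 1 to compound 3 (1.53 log units; beyond the scatter), so a second carbonyl-bearing compound now has a measured value. Compound 1 stands at a limit and not at a number, so this step has only a lower bound: the limit of > 10000 nM in this assay, at which 1 of the 3 values shown sits. With the carbonyl kept, the group on the carbonyl carbon also counts: oxan-4-yl in place of 3-methylcyclohexyl gives a 2.9-fold higher number from compound 2 to compound 3 (0.46 log units; beyond the scatter).

On these data alone, compound 1 and compound 3 differ in both the carbonyl and the ring it carries, so the share of each in the larger step stays open. Also open, as far as these compounds go, is how a phenyl ring, a short alkyl chain or an amine on the carbonyl carbon would read in this assay.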